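The compounds below may be only part of what the source reports. "The series", "measured", "known", "first", "only" and "open" are said of these compounds alone.

Compound 1 `Cc1cc(C)c2oc(NC(=O)CC3CCN(C(=O)OC(C)(C)C)CC3)nc2c1` and compound 2 `CC(=O)c1ccc(N2CCC(CC(=O)Nc3nc4cc(C)ccc4o3)CC2)cc1` share a core and were both tested in an ADME assay on microsomes from liver (Homo sapiens) for metabolic stability, with a stated time of 30 min; a lower number here means that less of the compound is left, a higher number that more of the compound is left. In this assay compound 1 gives 22%, while compound 2 gives 53%. Compound 2 thus stands highest of the two numbers, and its nearest neighbour, compound 1, lies lower by a gap beyond the scatter. Compound 1 carries a second methyl on its core, yet it also differs from compound 2 in other places, so no single step can be read from that pair. Compound 3 `CC(=O)c1ccc(N2CCC(CC(=O)Nc3nc4cc(C)cc(C)c4o3)CC2)cc1` is the next member. Its difference from compound 2 is methyl in place of hydrogen on an aromatic carbon. Among the compounds with values here, with no step between measured compounds that differ in one place to lean on, the expected change from compound 2 to compound 3 is small, amounting to a number 8 percentage points lower from compound 2 to compound 3 (within the scatter), not clearly beyond the scatter. Compound 3 is therefore estimated at 45%, within a range from 25% to 65%.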

Compound 3, percent of the compound remaining: 22%
Compound 3: the middle estimate sits 23 percentage points above what was measured, outside the stated range (below it).
By their numbers in this assay, from the lowest: compounds 1 and 3 (each within the scatter of the next); then compound 2.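

In this assay the change of methyl in place of hydrogen on an aromatic carbon, ortho to a fused ring and meta to a methyl group, gives a number 31 percentage points lower from compound 2 to compound 3 (beyond the scatter) and so shows that this one position on the shared core can by itself move the percent of compound remaining by a large step. With that methyl present, 4-acetylphenyl in place of tert-butoxycarbonyl on an amine nitrogen in a ring gives no change at the digits printed from compound 1 to compound 3 (within the scatter) and so leaves the two groups on that nitrogen not told apart by this read-out. Nothing given here explains the size of the methyl step.

Going by these compounds, whether a fluorine, a chlorine or a methoxy group at this same aromatic carbon would give a step like that of methyl stays open. Also open, on these data alone, is whether the exchange on the nitrogen would stay as flat on a core without this methyl.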